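A Methylsulfonyl Group Added to Compound 2

A few compounds are considered here, and "the series" means these few. Any claim that something is new, unique, unknown or untested is made for them only; others in the source may bear on it.

Compound 1 `COc1ccc(-c2ccnc(Nc3cccc(C(N)=O)c3)n2)cc1` gives 2700 nM
Compound 2 `NS(=O)(=O)c1cccc(Nc2nccc(-c3ccccc3)n2)c1` gives 800 nM
Compound 3 `COc1cccc(-c2ccnc(Nc3cccc(S(N)(=O)=O)c3)n2)c1` gives 1100 nM

In an ADME assay on Vero cells (Chlorocebus sabaeus) for cytotoxicity, read by MTT assay, with a stated time of 72 h (on this read-out lower numbers stand for stronger inhibition and higher numbers for weaker inhibition), compound 2 gives 800 nM and stands within the scatter of compound 3, while compound 1 gives 2700 nM as the higher number, beyond the scatter.

Compound 4 `CS(=O)(=O)c1ccc(-c2ccnc(Nc3cccc(S(N)(=O)=O)c3)n2)cc1` is compound 2 with methylsulfonyl in place of hydrogen on an aromatic carbon, para to a large group (methylsulfonyl in place of hydrogen on an aromatic carbon). Among the measured compounds shown here, the one measured step that bears on this is a 1.4-fold higher number from compound 2 to compound 3 (0.14 log units; within the scatter) for methoxy in place of hydrogen on an aromatic carbon, so no step beyond the scatter is expected in this assay for the new group either. For the measured compounds named here, compound 1 differs from compound 2 in more than one place and offers no single step. Going by the values given here, no compound with methylsulfonyl has been measured, so the guide is thin and the range stays wide. The estimated step is a 1.4-fold higher number from compound 2 to compound 4 (0.14 log units; within the scatter) and no more than that is expected. For compound 4 the estimated value is 1100 nM (expected range 400 nM to 3000 nM).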

Compound 4, half-maximal inhibitory concentration: > 100000 nM
Compound 4 gave a limit, no number (the forecaster's own chance of this, stated with the estimate: 3%); middle value at least 90-fold (1.95 log units) from the limit.
By their numbers in this assay, from the lowest: compounds 2 and 3 (each within the scatter of the next); then compound 1. At a limit, above all of these: compound 4.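

In this assay, methylsulfonyl on this six-membered aromatic ring of carbon only, para to a large group, gives an at least 120-fold higher number from compound 2 to compound 4 (2.09 log units; beyond the scatter). Substitution on this ring is therefore not always a small change in this assay, as the only earlier single step, for methoxy in place of hydrogen, was a 1.4-fold higher number from compound 2 to compound 3 (0.14 log units; within the scatter), though those two steps differ in both the group and its place. The reading for compound 4 is a limit of the assay, not a number: the limit of > 100000 nM in this assay, at which 1 of the 4 values shown sits.

On these data alone, how far compound 4 really lies from compound 2 stays open, as does whether the large step belongs to methylsulfonyl itself or to this place on the ring. An amine or a carboxylic acid in the same place would help to separate those two readings.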